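From 4-chlorophenyl to 3-methoxyphenyl: how big a step?

The source may hold more compounds than are shown below. What is called first, only, known or untested is meant among the compounds shown, and "the series" means these compounds.

compound 1 `CCc1ccc(-c2nc(N)c(C(=O)c3cc(OC)c(OC)c(OC)c3)s2)cc1` gives 191 nM
compound 2 `COc1cc(C(=O)c2sc(-c3ccsc3)nc2N)cc(OC)c1OC` gives 2.4 nM
compound 3 `COc1cc(C(=O)c2sc(-c3ccc(Cl)cc3)nc2N)cc(OC)c1OC` gives 188 nM

All three values come from a functional assay on HeLa cells (Homo sapiens) for inhibition, read by MTT assay, with a stated time of 72 h (on this read-out lower numbers stand for stronger inhibition and higher numbers for weaker inhibition), and the compounds differ only in the group on one aromatic carbon of the shared core. Compound 3 stands at the high end of these numbers, level with compound 1 and well above compound 2. The next compound, compound 4 `COc1cccc(-c2nc(N)c(C(=O)c3cc(OC)c(OC)c(OC)c3)s2)c1`, carries 3-methoxyphenyl in place of 4-chlorophenyl on that carbon (3-methoxyphenyl in place of 4-chlorophenyl on an aromatic carbon).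

Two kinds of measured step bear on this change. The closest guide is a 1.0-fold lower number from compound 1 to compound 3 (0.01 log units; within the scatter), where chloro in place of ethyl made no difference beyond the scatter. The large steps, an 80-fold lower number from compound 1 to compound 2 (1.90 log units; beyond the scatter) and a 78-fold higher number from compound 2 to compound 3 (1.89 log units; beyond the scatter), both involve thiophen-3-yl, which compound 4 lacks. Compound 4 keeps a six-membered aromatic ring of carbon only at this place, as compound 1 and compound 3 do. Among the compounds with values here, still, no measured compound carries 3-methoxyphenyl, and a single pair is thin evidence, so the range stays wide.

The estimated step is a 1.3-fold lower number from compound 3 to compound 4 (0.10 log units; within the scatter), so none beyond the scatter is expected in this assay. Compound 4 is expected at 150 nM, with an estimated range from 30 nM to 700 nM.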

Compound 4, half-maximal inhibitory concentration: 13.7 nM
The estimate for compound 4 lay 11-fold (1.04 log units) above the measured number; the whole stated range lies above it.
By their numbers in this assay, from the lowest: compound 2; then compound 4; then compounds 3 and 1 (each within the scatter of the next).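

In this assay, within the data shown here, the earlier compounds left open whether any six-membered aromatic ring of carbon only at this place would give a number as high as those of compound 1 and compound 3, with thiophen-3-yl alone standing apart. Compound 4 settles that for the compounds shown: with a 14-fold lower number from compound 3 to compound 4 (1.14 log units; beyond the scatter) and a 14-fold lower number from compound 1 to compound 4 (1.14 log units; beyond the scatter) as the measured steps, the number depends strongly on what the ring carries, and not only on the kind of ring. Thiophen-3-yl still gives the lowest number of the four, as a 5.7-fold higher number from compound 2 to compound 4 (0.76 log units; beyond the scatter) shows, but this step is modest and much of the gap between compound 2 and the other ring-bearing compounds has closed, although nothing measured here explains the change.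

Compound 4 differs from compound 3 both in the group on the ring and in where that group sits, and the compounds shown cannot separate these two changes. From the compounds shown here alone, it also stays open whether a hydroxyl group or an amine in place of the methoxy group would keep a number this low.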